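A Lone Measured Value and a Lost Methoxymethoxy Group

A few compounds are considered here, and "the series" means these few. Any claim that something is new, unique, unknown or untested is made for them only; others in the source may bear on it.

Among the measured compounds shown here, in an ADME assay on PA-1 cells (Homo sapiens) for cytotoxicity, read by MTT assay, with a stated time of 72 h (a lower number here means a stronger inhibitor, a higher number a weaker inhibitor), compound 3 (`COCOc1cc(C2=C(c3cc(OC)c(OC)c(OC)c3)C(=O)CC2O[SiH2]C(C)(C)C)ccc1OC`) gives 13.5 ug/mL, the only actual number among the three compounds measured. Compound 1 (`COC(=O)c1cc(C2=C(c3cc(OC)c(OC)c(OC)c3)C(=O)CC2O[SiH2]C(C)(C)C)ccc1OC`) is reported only as a limit, > 100 ug/mL. Compound 2 (`COc1ccc(C2=C(c3cc(OC)c(OC)c(OC)c3)C(=O)CC2O[SiH2]C(C)(C)C)cc1OC`) is likewise reported only as a limit, > 100 ug/mL. For the measured compounds named here, the series so far is thus defined by the limit of > 100 ug/mL in this assay, at which 2 of the 3 values shown sit. Between these two limits lies a step that the two limits leave unreadable from compound 1 to compound 2. The two readable steps are an at least 7.4-fold lower number from compound 1 to compound 3 (0.86 log units; beyond the scatter) and an at least 7.4-fold lower number from compound 2 to compound 3 (0.86 log units; beyond the scatter).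

Compound 4 (`COc1cc(C2=C(c3cc(C)c(OC)c(C)c3)C(O[SiH2]C(C)(C)C)CC2=O)cc(OC)c1OC`) departs from compound 3 by 4-methoxy-3,5-dimethylphenyl in place of 4-methoxy-3-(methoxymethoxy)phenyl on a double-bonded ring carbon, with 4-methoxy-3,5-dimethylphenyl in place of 4-methoxy-3-(methoxymethoxy)phenyl on a double-bonded ring carbon. Like compound 2, compound 4 carries no methoxymethoxy group, and the closest measured guide is an at least 7.4-fold lower number from compound 2 to compound 3 (0.86 log units; beyond the scatter), read here in reverse. Going by the values given here, no measured step covers the two methyl groups, so this guide is only partial. The expected change in this assay is a 4.4-fold higher number from compound 3 to compound 4 (0.65 log units; beyond the scatter), toward a higher number and so a weaker inhibitor. Compound 4 is estimated at 60 ug/mL, with an expected range of 15 ug/mL to 200 ug/mL, and a report of only a limit would not be surprising.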

Compound 4, half-maximal inhibitory concentration: 32 ug/mL
Estimate against measurement, compound 4: 1.9-fold (0.27 log units) above; the measured number falls inside the stated range.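

Compound 4 shows that this position, a double-bonded ring carbon of the five-membered ring, can give a measured value without a methoxymethoxy group: 4-methoxy-3,5-dimethylphenyl yields an at least 3.1-fold lower number from compound 2 to compound 4 (0.49 log units; beyond the scatter) and an at least 3.1-fold lower number from compound 1 to compound 4 (0.49 log units; beyond the scatter). Yet in this assay the same position also shows a cost when 4-methoxy-3-(methoxymethoxy)phenyl gives way to 4-methoxy-3,5-dimethylphenyl, with a 2.4-fold higher number from compound 3 to compound 4 (0.37 log units; beyond the scatter), so the methoxymethoxy-bearing ring remains ahead of this replacement by a step beyond the scatter. Compound 1 and compound 2 remain limits and not numbers, and the step between them cannot be read, which leaves compound 3 and compound 4 as the only pair with two real numbers: the limit of > 100 ug/mL in this assay, at which 2 of the 4 values shown sit.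

The compounds shown do not separate what the two methyl groups of compound 4 contribute from what the loss of the methoxymethoxy group contributes, and a ring with a single methyl would bear on that question. Going by these compounds, it also stays open how a free hydroxyl or an amine would read on this phenyl ring, and whether the group of 6 heavy atoms shared by all four compounds matters.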